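Replacing Piperidin-1-yl with Dimethylamino on the Shared Core

This account rests on a few compounds, and the source may have more. Where it says the series, first, only, none or still open, it means among the compounds named here.

In an ADME assay on L6 cells (Rattus norvegicus) for cytotoxicity, read by resazurin assay, with a stated time of 72 h (a lower number here means a stronger inhibitor, a higher number a weaker inhibitor), compound 3 (`NC1CC2(N3CCCCC3)CC(c3ccccc3)C1C(c1ccccc1)C2`) gives 35000 nM. This lies within the usual scatter of compound 1 (`CN(C)C12CC(OC(=O)CN3CCCC3)C(C(c3ccccc3)C1)C(c1ccccc1)C2`) at 32700 nM and compound 2 (`CN1CCN(CC(=O)OC2CC3(N(C)C)CC(c4ccccc4)C2C(c2ccccc2)C3)CC1`) at 39900 nM. Compound 4 (`CN(C)C12CC(N)C(C(c3ccccc3)C1)C(c1ccccc1)C2`) has not yet been measured. It differs from compound 3 in one place: dimethylamino in place of piperidin-1-yl on a saturated ring carbon.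

Among the compounds with values here, no measured step shows this exact swap. Compound 1 and compound 2 already carry dimethylamino on the core, but they also differ from compound 3 elsewhere, so they offer only indirect guidance. Within the data shown here, the one measured step changes a different group and stays within the scatter: a 1.2-fold higher number from compound 1 to compound 2 (0.09 log units; within the scatter). With so little spread in these values, no shift beyond the scatter is expected in this assay, and the estimated step is no change at the digits printed from compound 3 to compound 4 (within the scatter). For compound 4 the estimated value is 35000 nM, with an expected range from 16000 nM to 70000 nM.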

Compound 4, half-maximal inhibitory concentration: 40900 nM
The estimate for compound 4 lay 1.2-fold (0.07 log units) below the measured number; measured number inside the range.
By their numbers in this assay, from the lowest: compounds 1, 3, 2 and 4 (each within the scatter of the next).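

In this assay, within the data shown here, this is the first direct reading of the swap on this saturated ring carbon: dimethylamino in place of piperidin-1-yl removes the six-membered ring, yet the step stays within the scatter (a 1.2-fold higher number from compound 3 to compound 4 (0.07 log units; within the scatter)). Compound 4 also shows that the larger ester-linked groups of the two earlier compounds can give way to a plain amino group with no shift beyond the scatter, whether the group replaced carries 4-methylpiperazin-1-yl (a 1.0-fold higher number from compound 2 to compound 4 (0.01 log units; within the scatter)) or pyrrolidin-1-yl (a 1.3-fold higher number from compound 1 to compound 4 (0.10 log units; within the scatter)). No supporting measurement is available to explain this lack of movement.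

The compounds shown do not reveal whether a carboxylic acid or a longer carbon chain on this ring carbon would move the number beyond the scatter. Nor do they show whether any group at either changed place can do so.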